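Shifting Fluorine From 2-Fluorophenyl to 3-Fluorophenyl

The compounds below may be only part of what the source reports. "The series", "measured", "known", "first", "only" and "open" are said of these compounds alone.

Three compounds have been measured in a functional assay on OVCAR-3 cells (Homo sapiens) for antiproliferative activity, read by MTT assay, with a stated time of 24 h; on this read-out higher numbers stand for weaker inhibition and lower numbers for stronger inhibition:

Compound 1, `O=c1[nH]cc(S(=O)(=O)Nc2ccccc2-c2cn(-c3ccccc3F)nn2)c(=O)[nH]1`, gives 15300 nM.
Compound 2, `O=c1[nH]cc(S(=O)(=O)Nc2ccccc2-c2cn(-c3cccc(F)c3)nn2)c(=O)[nH]1`, gives only a limit of the assay, > 20000 nM.
Compound 3, `O=c1[nH]cc(S(=O)(=O)Nc2cccc(-c3cn(-c4ccccc4F)nn3)c2)c(=O)[nH]1`, gives 12500 nM.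

Compound 1 and compound 3 have the same atoms joined differently; the difference between the two cores is not broken down here. Their two values lie within the usual scatter of each other. Going by these compounds, the change 3-fluorophenyl in place of 2-fluorophenyl on an aromatic nitrogen produced an at least 1.3-fold higher number from compound 1 to compound 2 (0.11 log units; that floor lies within the scatter), and because of the limit of > 20000 nM in this assay, at which 1 of the 3 values shown sits, the true size of that step stays open.

Compound 4, `O=c1[nH]cc(S(=O)(=O)Nc2cccc(-c3cn(-c4cccc(F)c4)nn3)c2)c(=O)[nH]1`, carries the same change relative to compound 3: 3-fluorophenyl in place of 2-fluorophenyl on an aromatic nitrogen. Compound 4 is expected to give 18000 nM, most likely between 9000 nM and 40000 nM. That expectation rests on the step of an at least 1.3-fold higher number from compound 1 to compound 2 (0.11 log units; that floor lies within the scatter). Compound 4 is thus estimated to show a 1.4-fold higher number from compound 3 to compound 4 (0.16 log units; within the scatter), with a real chance that only a limit is reported.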

Compound 4, half-maximal inhibitory concentration: > 20000 nM
Compound 4: only a limit was reported (the forecaster's own chance of this, stated with the estimate: 40%); middle value at least 1.1-fold (0.04 log units) away from the limit.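

In this assay, compound 4 gives only a limit of the assay, > 20000 nM. The change to 3-fluorophenyl in place of 2-fluorophenyl therefore appears as an at least 1.6-fold higher number from compound 3 to compound 4 (0.20 log units; that floor lies within the scatter), a floor rather than a true size. Set beside the same change on the other core, the two floors show that both steps end at the limit, but they do not show that the change has a real effect on either core or the same effect on both: the same change on two cores in this assay, an at least 1.3-fold higher number (0.11 log units; that floor lies within the scatter) from compound 1 to compound 2 and an at least 1.6-fold higher number (0.20 log units; that floor lies within the scatter) from compound 3 to compound 4; the limit leaves it open whether they differ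

The compounds shown carry only fluorine on this phenyl ring. Going by these compounds, whether a chlorine atom, a methoxy group or an amine in its place would give a measurable number on either core remains open.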